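Chain swap on the core of compound 2

This account rests on a few compounds, and the source may have more. Where it says the series, first, only, none or still open, it means among the compounds named here.

Measured in a functional assay on MCF7 cells (Homo sapiens) for antiproliferative activity, read by MTT assay (a lower number here means a stronger inhibitor, a higher number a weaker inhibitor), so far
- compound 1 `CCCC/C=C\CCCCCCCCCc1cc(=O)c2c(O)cc(O)c(C)c2o1` gives 17500 nM
- compound 2 `CC/C=C\C/C=C\C/C=C\CCCCCCCc1cc(=O)c2c(O)c(C)c(O)c(C)c2o1` gives 17500 nM

Within the data shown here, compound 2 stands level with compound 1, within the scatter, and no measured step in a single place is available. Compound 3 `CCCC/C=C\CCCCCCCCCc1cc(=O)c2c(O)c(C)c(O)c(C)c2o1` keeps the core of compound 2 and takes oct-3-en-1-yl in place of the longer chain, with the change a group of 8 heavy atoms (8 carbon; no ring) in place of a group of 10 heavy atoms (10 carbon; no ring), on a saturated chain carbon, seven bonds along the chain from an aromatic carbon on that chain. This is the chain of compound 1, so compound 3 pairs the chain of compound 1 with the core of compound 2. Among the measured compounds shown here, with compound 1 at 17500 nM and compound 2 at 17500 nM as the only guide, no step beyond the scatter is expected in this assay here. The estimated change no change at the digits printed from compound 2 to compound 3 (within the scatter) is therefore expected to stay within the scatter. For compound 3 the expected value is 17500 nM with an estimated range from 8000 nM to 35000 nM as a working figure.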

Compound 3, half-maximal inhibitory concentration: > 67200 nM
Compound 3: only a limit was reported (the forecaster's own chance of this, stated with the estimate: 8%); middle value at least 3.8-fold (0.58 log units) away from the limit.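

In this assay compound 3 gives > 67200 nM, which is a limit of the assay and not a number. Two single changes can now be read: oct-3-en-1-yl in place of the longer chain gives an at least 3.8-fold higher number from compound 2 to compound 3 (0.58 log units; beyond the scatter), and methyl in place of hydrogen on an aromatic carbon gives an at least 3.8-fold higher number from compound 1 to compound 3 (0.58 log units; beyond the scatter). The level standing of compound 1 and compound 2 therefore does not carry over to this pairing, so chain and core cannot be swapped freely here.

Going by these compounds, the true size of both steps stays open. On these data alone, it is also open how a saturated chain of the same length, or a chain ending in a carboxylic acid or an amine, would behave on the core of compound 2.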